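A few compounds are considered here, and "the series" means these few. Any claim that something is new, unique, unknown or untested is made for them only; others in the source may bear on it.

For the measured compounds named here, in a physicochemical assay for solubility, with a stated time of 3 days, at pH 7 (on this read-out lower numbers stand for lower solubility and higher numbers for higher solubility), compound 3 `NC(=O)c1ccc2[nH]c(-c3ccc(OCCC4CCCCN4Cc4ccccc4)cc3)nc2c1` gives 155000 nM and is the only compound of this small set with a number. Compound 1 `CN1CCC(Oc2ccc(-c3nc4cc(C(N)=O)ccc4[nH]3)cc2)C1` has "not determined" (no result reported) as its entry and compound 2 `COc1ccc(CN2CCC(COc3ccc(-c4nc5cc(C(N)=O)ccc5[nH]4)cc3)CC2)cc1` has "not determined" (no result reported) as its entry. Compound 3 therefore cannot yet be ranked as high or low against its relatives.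

Compound 4 `NC(=O)c1ccc2[nH]c(-c3ccc(OCCC4CCCCN4Cc4ccc(Cl)c(Cl)c4)cc3)nc2c1` keeps the shared core of compound 3 and differs in one place. The change 3,4-dichlorophenyl in place of phenyl on a saturated chain carbon bound to an amine nitrogen in a ring puts 3,4-dichlorophenyl in place of phenyl on a saturated chain carbon bound to an amine nitrogen in a ring. Seen one bond further out, benzyl becomes 3,4-dichlorobenzyl.

Going by the values given here, no pair of measured compounds shows what a single change does here, and that leaves the forecast resting on judgement and carrying a wide range. The expected step of a 3.4-fold lower number from compound 3 to compound 4 (0.54 log units; beyond the scatter) is a fall clearly larger than the ordinary scatter of repeat measurements in this assay for this pair. Compound 4 is expected at 45000 nM within a range of 12000 nM to 130000 nM as an estimate only.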

Compound 4, solubility: 229000 nM
The estimate for compound 4 lay 5.1-fold (0.71 log units) below the measured number, outside the stated range (above it).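

In this assay, for the compounds shown here, the first step that can be read at this place is a 1.5-fold higher number from compound 3 to compound 4 (0.17 log units; within the scatter), so the two compounds cannot be told apart on this read-out. Putting 3,4-dichlorophenyl in place of phenyl adds two chlorine atoms to the group, with no hydrogen-bond donors or acceptors on either side, and this pair shows no step beyond the scatter for that change. No measured property of either group is available to account for this result.

A single pair cannot say whether other groups at this place would behave the same way: a pyridyl ring in place of phenyl, or a carboxylic acid on the phenyl ring, could give a step of quite different size. It also leaves open whether the same change would give a similar step on a longer chain.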